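The source may hold more compounds than are shown below. What is called first, only, known or untested is meant among the compounds shown, and "the series" means these compounds.

Compound 1, `Cc1cn([C@@H]2C[C@H](O)[C@@H](CNC(=O)Nc3ccc(C(C)(C)C)cc3)O2)c(=O)[nH]c1=O`, was tested in an ADME assay on MRC5 cells (Homo sapiens) for cytotoxicity; on this read-out lower numbers stand for higher toxicity in this test and higher numbers for lower toxicity in this test. In this assay compound 1 reaches only a limit of the test, > 50000 nM, and not a number. Compound 2, `Cc1cn([C@@H]2C[C@H](O)[C@@H](CNC(=O)Nc3cccc(COc4ccccc4)c3)O2)c(=O)[nH]c1=O`, likewise stops at a limit, giving > 50000 nM in this assay. Compound 3, `Cc1cn([C@@H]2C[C@H](O)[C@@H](CNC(=O)Nc3ccc(OC4CCOCC4)cc3)O2)c(=O)[nH]c1=O`, also ends at a limit, with > 50000 nM in this assay. Among the compounds with values here, the one measured step that alters a single place, a step that the two limits leave unreadable from compound 1 to compound 3, cannot be read in size because of the limit of > 50000 nM in this assay, at which 3 of the 3 values shown sit. Compound 4, `Cc1cn([C@@H]2C[C@H](O)[C@@H](CNC(=O)Nc3ccc(OCc4ccc(C(C)(C)C)cc4)cc3)O2)c(=O)[nH]c1=O`, differs from compound 1 by (4-(tert-butyl)benzyl)oxy in place of tert-butyl on an aromatic carbon. Within the data shown here, since every value shown stops at the limit, no measured step gives a direction, and no shift beyond the scatter is expected. The step of a number no higher from compound 1 to compound 4 (the limit leaves the size open) is therefore estimated as flat. For compound 4 the expected value is 50000 nM, within a range from 20000 nM to 100000 nM.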

Compound 4, half-maximal cytotoxic concentration: > 50000 nM
Compound 4: only a limit was reported (the forecaster's own chance of this, stated with the estimate: 70%); the middle value lies on the limit itself.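

Compound 4 also stops at a limit, so the steps to it from compound 1 and compound 3 cannot be read in size: the limit of > 50000 nM in this assay, at which 4 of the 4 values shown sit. The compounds shown leave open which change, if any, would give a real number in this assay.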